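Sulfonyl aryl variation on a shared indazolyl-indole core

A few compounds are considered here, and "the series" means these few. Any claim that something is new, unique, unknown or untested is made for them only; others in the source may bear on it.

Measured so far:
compound 1 `CN(c1ccc2[nH]c(-c3n[nH]c4ccccc34)cc2n1)S(=O)(=O)c1ccccc1` — 6740 nM
compound 2 `CN(c1ccc2[nH]c(-c3n[nH]c4ccccc34)cc2n1)S(=O)(=O)c1ccc(Br)cc1` — 9850 nM

Compound 1 and compound 2 differ only in the substituent on the sulfonyl aryl ring; in a functional assay on HCT-116 cells (Homo sapiens) for antiproliferative activity, read by MTT assay, with a stated time of 72 h (on this read-out higher numbers stand for weaker inhibition and lower numbers for stronger inhibition), compound 1 gives 6740 nM and compound 2 gives 9850 nM. The single step in hand, a 1.5-fold higher number from compound 1 to compound 2 (0.16 log units; within the scatter), stays within the scatter, so on the two numbers shown compound 2 sits at the high end of the pair, although not separated from compound 1 beyond the scatter.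

Compound 3 `COc1ccc(S(=O)(=O)N(C)c2ccc3[nH]c(-c4n[nH]c5ccccc45)cc3n2)cc1OC` is unmeasured. The change from compound 2 is 3,4-dimethoxyphenyl in place of 4-bromophenyl on a sulfonyl sulfur. Within the data shown here, only the step from compound 1 to compound 2 bears on this part of the molecule, and it was small; there is no measured step for a methoxy-bearing sulfonyl aryl ring, so nothing argues for a move beyond the scatter in either direction. The working expectation for compound 3 in this assay is therefore a step of a 1.3-fold lower number from compound 2 to compound 3 (0.12 log units; within the scatter), essentially flat. Compound 3 is estimated at 7500 nM, with a range from 2500 nM to 25000 nM.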

Compound 3, half-maximal inhibitory concentration: 16700 nM
Compound 3: the middle estimate sits 2.2-fold (0.35 log units) below what was measured; the range from low to high includes it.
By their numbers in this assay, from the lowest: compounds 1, 2 and 3 (each within the scatter of the next, the first and the last beyond it).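

In this assay, among these compounds, the step of a 2.5-fold higher number from compound 1 to compound 3 (0.39 log units; beyond the scatter) is the first change on the sulfonyl sulfur to pass beyond the scatter, so this position is not fully flat: 3,4-dimethoxyphenyl in place of phenyl moves the number toward weaker inhibition, though only modestly. The same ring in place of 4-bromophenyl gives a 1.7-fold higher number from compound 2 to compound 3 (0.23 log units; within the scatter) and stays within the scatter, so the 4-bromophenyl and 3,4-dimethoxyphenyl compounds cannot be put in order, and the separation holds only against the phenyl compound. Nothing available explains the shift between compound 1 and compound 3.

The compounds shown cannot tell whether one methoxy group on the ring, as in 4-methoxyphenyl, would already give the shift or whether both methoxy groups are needed. They also leave open whether any sulfonyl aryl ring, for instance one carrying an amine or a carboxylic acid, or a small alkyl chain on the sulfonyl sulfur in place of the ring, would give a lower number than compound 1 at 6740 nM in this assay.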